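Chloropyrazole in Place of Difluoropiperidine on the Glycinamide Arm

The compounds below may be only part of what the source reports. "The series", "measured", "known", "first", "only" and "open" are said of these compounds alone.

In a functional assay on CHO-K1 cells for antagonist activity at C-X-C chemokine receptor type 3 (Homo sapiens), read by FLIPR, with a stated time of 10 min, in the presence of a further agent that is not named here (on this read-out higher numbers stand for weaker inhibition and lower numbers for stronger inhibition), two compounds built on a shared core have been measured. Compound 1 `C[C@@H]1CN(c2sc(C(F)(F)F)nc2-c2nc3ccccc3[nH]2)CCN1C(=O)CN1C(=O)OC[C@@H]1c1ccccc1` gives 360 nM, and compound 2 `C[C@@H]1CN(c2sc(C(F)(F)F)nc2-c2nc3ccccc3[nH]2)CCN1C(=O)CN1CCC(F)(F)CC1` gives 15 nM. Among the measured compounds shown here, the single measured step between them is a 24-fold lower number from compound 1 to compound 2 (1.38 log units; beyond the scatter), and it leaves compound 2 with the lowest number of the two, compound 1 being its nearest neighbour.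

Compound 3 `C[C@@H]1CN(c2sc(C(F)(F)F)nc2-c2nc3ccccc3[nH]2)CCN1C(=O)Cn1cc(Cl)cn1` differs from compound 2 in one place: 4-chloro-1H-pyrazol-1-yl in place of 4,4-difluoropiperidin-1-yl on a saturated chain carbon bound to a carbonyl carbon. For the measured compounds named here, no measured step covers this exact exchange. Going by the values given here, the only step available, from compound 1 to compound 2, also replaced a group on the saturated chain carbon bound to a carbonyl carbon and was large, which shows that this position is sensitive to what is attached there; but the group it brought in is the very one that now leaves, so it gives no direction for the 4-chloro-1H-pyrazol-1-yl group. A moderate move toward a higher number is therefore expected, a 3.0-fold higher number from compound 2 to compound 3 (0.48 log units; beyond the scatter), with wide uncertainty. Compound 3 is estimated at 45 nM, expected to fall between 10 nM and 250 nM.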

Compound 3, half-maximal inhibitory concentration: 1.7 nM
For compound 3 the middle estimate is 26-fold (1.42 log units) above the measured one; the measured number lies below the stated range.
By their numbers in this assay, from the lowest: compound 3; then compound 2; then compound 1.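

In this assay, the exchange gives an 8.8-fold lower number from compound 2 to compound 3 (0.95 log units; beyond the scatter), which shows that the 4,4-difluoropiperidin-1-yl group did not mark the limit of what this place on the saturated chain carbon bound to a carbonyl carbon can give. Set against the 2-oxo-4-phenyl-1,3-oxazolidin-3-yl group, the 4-chloro-1H-pyrazol-1-yl group gives a 210-fold lower number from compound 1 to compound 3 (2.33 log units; beyond the scatter), so the three groups now spread widely on the shared core, and compound 3 has the lowest number, with its steps to both others beyond the scatter. The exchange swaps a six-membered non-aromatic ring for a five-membered aromatic one and two fluorine atoms for one chlorine atom, all in a single step, and no measurement at hand explains the drop in the number.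

Still open, going by these compounds, is which part of the exchange matters: an unsubstituted 1H-pyrazol-1-yl group, a 4-methyl-1H-pyrazol-1-yl group or a 4-cyano-1H-pyrazol-1-yl group would test the chlorine, and an imidazol-1-yl or 1,2,4-triazol-1-yl group would test the ring. On these data alone, all three compounds share one core, and whether the same order holds on any other core also stays open.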